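Swapping an ether-bearing group for a cyclopropane-bearing group

The compounds below may be only part of what the source reports. "The series", "measured", "known", "first", "only" and "open" are said of these compounds alone.

Measured in an ADME assay on Caco-2 cells (Homo sapiens) for permeability, read by LC-MS, in the apical to basolateral direction, with a stated time of 60 min, at pH 6.5; a higher number here means that the compound crosses the layer faster, a lower number that the compound crosses the layer more slowly:
Compound 1 `O=C(NCc1cc(Cl)ccc1-n1cnnn1)[C@@H]1[C@@H]2C[C@@H]2CN1C(=O)[C@H](O)Cc1ccccn1`: 0.62 10^-6 cm/s
Compound 2 `COC(C)(C)[C@@H](O)C(=O)N1C[C@H]2C[C@H]2[C@H]1C(=O)NCc1cc(Cl)ccc1-n1cnnn1`: 3.5 10^-6 cm/s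

Of the two compounds measured, compound 2 holds the higher number. Compound 3 `CC1(C[C@@H](O)C(=O)N2C[C@H]3C[C@H]3[C@H]2C(=O)NCc2cc(Cl)ccc2-n2cnnn2)CC1` differs from compound 2 at one place: (1-methylcyclopropyl)methyl in place of 1-methoxy-1-methylethyl ((1-methylcyclopropyl)methyl in place of 1-methoxy-1-methylethyl on a saturated chain carbon bound to a carbonyl carbon and an oxygen on a saturated carbon). Among the compounds with values here, the only measured step at this place, a 5.6-fold higher number from compound 1 to compound 2 (0.75 log units; beyond the scatter), involved a different pair of groups, so it offers only a loose guide. No measurement covers this exact swap. The expected step is small and within the scatter: a 1.4-fold higher number from compound 2 to compound 3 (0.15 log units; within the scatter). For compound 3 the estimated value is 5 10^-6 cm/s, with an expected range from 2 10^-6 cm/s to 12 10^-6 cm/s.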

Compound 3, apparent permeability: 2.2 10^-6 cm/s
Compound 3: the middle estimate sits 2.3-fold (0.36 log units) above what was measured; the range from low to high includes it.
By their numbers in this assay, from the lowest: compound 1; then compounds 3 and 2 (each within the scatter of the next).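

In this assay, (1-methylcyclopropyl)methyl in place of 1-methoxy-1-methylethyl gives a 1.6-fold lower number from compound 2 to compound 3 (0.20 log units; within the scatter) and so does not separate these two groups, even though only the leaving group carries an oxygen. Compound 1 remains apart from both, as 1-methylcyclopropyl in place of pyridin-2-yl gives a 3.5-fold higher number from compound 1 to compound 3 (0.55 log units; beyond the scatter) and stays beyond the scatter. No measured evidence here explains either step.

Going by these compounds, it remains open whether a simple neopentyl group, with no ring or oxygen, would fall in the same range. An amine or a carboxylic acid at this place is also untested in the compounds shown.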